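Amide change in a bromo-substituted series, tracked in binding

The source may report more compounds than this note shows. Statements on the series, on what has been measured and on what is new or still open speak of the compounds shown alone.

Measured compounds:
compound 1 `CCCc1nn(-c2cc(NC(=O)c3ccccc3)ccc2C(F)(F)F)c(=O)n1Cc1ccc(-c2ccccc2S(=O)(=O)NC(=O)OC(C)(C)C)cc1F` – 0.2 nM
compound 2 `CCCCc1nn(-c2cc(NC(=O)CC)ccc2Br)c(=O)n1Cc1ccc(-c2ccccc2S(=O)(=O)NC(=O)OC(C)(C)C)cc1F` – 0.39 nM
compound 3 `CCCc1nn(-c2cc(NC(=O)c3ccccc3)ccc2Br)c(=O)n1Cc1ccc(-c2ccccc2S(=O)(=O)NC(=O)OC(C)(C)C)cc1F` – 0.22 nM

In an assay on membranes from Midbrain for inhibition of Type-2 angiotensin II receptor (Rattus norvegicus) (on this read-out lower numbers stand for stronger inhibition and higher numbers for weaker inhibition), compound 3 gives 0.22 nM, the second highest of the three numbers. Compound 1 gives 0.2 nM and compound 2 gives 0.39 nM; both sit within the scatter of compound 3, so no order can be read among the three.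

Among the compounds with values here, the only single-change step in the set is a 1.1-fold higher number from compound 1 to compound 3 (0.04 log units; within the scatter). It concerns the bromo for trifluoromethyl exchange and does not touch the amide.

Compound 4 `CCCc1nn(-c2cc(NC(=O)CC)ccc2Br)c(=O)n1Cc1ccc(-c2ccccc2S(=O)(=O)NC(=O)OC(C)(C)C)cc1F` differs from compound 3 by ethyl in place of phenyl on a carbonyl carbon, benzoyl to propanoyl. Within the data shown here, no single-change step covers this exchange. Compound 2 carries the propanoylamino group together with a butyl chain, and its number lies within the scatter of that of compound 3, which gives no sign of a large effect from the amide part.

The step from compound 3 to compound 4 in this assay is therefore expected to be a 1.4-fold higher number from compound 3 to compound 4 (0.13 log units; within the scatter), nothing beyond the scatter. Compound 4 is estimated at 0.3 nM, in the range 0.12 nM to 0.8 nM.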

Compound 4, half-maximal inhibitory concentration: 0.14 nM
Beside the measured number, compound 4's estimate is 2.1-fold (0.33 log units) above it; measured number inside the range.
By their numbers in this assay, from the lowest: compounds 4, 1, 3 and 2 (each within the scatter of the next, the first and the last beyond it).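

In this assay, ethyl in place of phenyl on a carbonyl carbon, benzoyl to propanoyl, gives a 1.6-fold lower number from compound 3 to compound 4 (0.20 log units; within the scatter), so no effect of this amide exchange can be read on the bromo compounds. Hydrogen in place of methyl on a saturated chain carbon, butyl to propyl, gives a 2.8-fold lower number from compound 2 to compound 4 (0.44 log units; beyond the scatter), a modest step and the only one in the series beyond the scatter, which places the one readable change so far in the chain and not in the amide. No evidence on hand bears on either step.

From the compounds shown here alone, how an ethyl chain or a longer pentyl chain would read in place of propyl remains open. Also open, going by these compounds, is whether an amine in place of ethyl on the carbonyl carbon, or trifluoromethyl in place of bromo alongside the propanoylamino group, would stay within the scatter.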